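Fluoro on the benzyl group of compound 2

A few compounds are considered here, and "the series" means these few. Any claim that something is new, unique, unknown or untested is made for them only; others in the source may bear on it.

Among the measured compounds shown here, in a functional assay for inhibition, with Homo sapiens as the target (a lower number here means tighter binding, a higher number weaker binding), compound 2 (`CC(C)(Cc1ccccc1)C1OCC(C/C=C\CCC(=O)O)C(c2cccnc2)O1`) gives 513 nM, the higher of the two numbers so far, while compound 1 (`Cc1ccc(C#N)c(OC(C)(C)C2OCC(C/C=C\CCC(=O)O)C(c3cccnc3)O2)c1`) gives 15.9 nM. Compound 3 (`CC(C)(Cc1ccc(F)cc1)C1OCC(C/C=C\CCC(=O)O)C(c2cccnc2)O1`) carries fluoro in place of hydrogen on an aromatic carbon, para to a large group, which turns benzyl to 4-fluorobenzyl: fluoro in place of hydrogen on an aromatic carbon. For the measured compounds named here, the only measured step, a 32-fold higher number from compound 1 to compound 2 (1.51 log units; beyond the scatter), is large but exchanges a whole group, so it sets no size for a single fluoro. No step beyond the scatter is expected in this assay. The expected step is a 1.2-fold lower number from compound 2 to compound 3 (0.09 log units; within the scatter). For compound 3 the estimate is 420 nM, with an expected range of 160 nM to 1100 nM.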

Compound 3, dissociation constant: 89.1 nM
Compound 3: the middle estimate sits 4.7-fold (0.67 log units) above what was measured; measured number outside the range, below it.
By their numbers in this assay, from the lowest: compound 1; then compound 3; then compound 2.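

A single fluoro on an aromatic carbon, para to a large group, gives (a 5.8-fold lower number from compound 2 to compound 3 (0.76 log units; beyond the scatter)) in this assay, so this position responds to one added heavy atom and not only to exchange of the whole group. The 4-fluorobenzyl group still falls short of the group in compound 1, with (a 5.6-fold higher number from compound 1 to compound 3 (0.75 log units; beyond the scatter)) remaining. No supporting evidence bears on this change.

As far as these compounds go, whether chloro or methoxy in the same place would lower the number further remains open. So does whether the gain from fluoro would carry over to the group in compound 1.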